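Trimming the methoxybenzyl arm: a phenyl-for-benzyl swap

A few compounds are considered here, and "the series" means these few. Any claim that something is new, unique, unknown or untested is made for them only; others in the source may bear on it.

Measured compounds:
compound 1, `CCOC(=O)CN(Cc1ccccc1)c1nc(NCc2cccc(OC)c2)ncc1[N+](=O)[O-]`, 80700 nM
compound 2, `CCOC(=O)CNc1nc(NCc2ccccc2)ncc1[N+](=O)[O-]`, 22300 nM

Of the compounds shown here, two have been measured in a functional assay on MDA-MB-231 cells (Homo sapiens) for antiproliferative activity, read by MTT assay, with a stated time of 48 h; on this read-out lower numbers stand for stronger inhibition and higher numbers for weaker inhibition. Compound 1 gives 80700 nM in this assay, the higher of the two numbers. For the measured compounds named here, compound 2 gives 22300 nM in this assay, a lower number that lies beyond the scatter of the read-out, although compound 2 differs from compound 1 in more than one place and so no single step can be drawn between them.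

The next compound, compound 3, `CCOC(=O)CN(Cc1ccccc1)c1nc(Nc2ccccc2)ncc1[N+](=O)[O-]`, keeps everything of compound 1 except one arm: phenyl in place of 3-methoxybenzyl on a nitrogen on an aromatic ring. Put the other way, the (3-methoxybenzyl)amino group becomes an anilino group.

Going by the values given here, nothing measured so far isolates this change, so any expectation rests on compound 1 alone. The step from compound 1 to compound 3, a 1.2-fold lower number from compound 1 to compound 3 (0.06 log units; within the scatter), is expected to be small, with no confident direction beyond the scatter. Compound 3 is therefore estimated at 70000 nM in this assay, within a range from 25000 nM to 200000 nM.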

Compound 3, half-maximal inhibitory concentration: > 100000 nM
Compound 3: only a limit was reported (the forecaster's own chance of this, stated with the estimate: 25%); middle value at least 1.4-fold (0.15 log units) from the limit.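

In this assay, compound 3 gives > 100000 nM, which is a limit of the assay and not a number. Phenyl in place of 3-methoxybenzyl on a nitrogen on an aromatic ring gives an at least 1.2-fold higher number from compound 1 to compound 3 (0.09 log units; that floor lies within the scatter), so this first reading of the arm shows no gain from the anilino group, while the true size of the step stays unknown. Only the floor of that step can be read, and the reading of compound 3 sits at the edge of what the assay reports: the limit of > 100000 nM in this assay, at which 1 of the 3 values shown sits.

The swap takes away the methoxy group and the carbon link to the ring together, so the compounds shown leave open which of the two matters, a question that a plain benzylamino group or a 3-methoxyanilino group in the same place could separate. They also leave open how a longer chain such as 2-phenylethylamino, or a ring of another kind such as cyclohexylamino, would read at this position.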